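Dropping One Methyl From a Very Weak Inhibitor

The source may hold more compounds than are shown below. What is called first, only, known or untested is meant among the compounds shown, and "the series" means these compounds.

Compound 1 `COc1ccc(CNC(=O)/C=C/c2coc3cc(O)ccc3c2=O)cc1`: 10000 nM in a functional assay (QGY7701 cells, Homo sapiens) for inhibition, read by MTT assay, with a stated time of 48 h; a lower number here means a stronger inhibitor, a higher number a weaker inhibitor
Compound 2 `COc1ccc2c(=O)c(/C=C/C(=O)Nc3cc(C)ccc3C)coc2c1`: > 100000 nM

In this assay compound 1 gives 10000 nM. On these data alone, compound 2 shows only a limit of the assay, > 100000 nM, so it stands at the limit of > 100000 nM in this assay, at which 1 of the 2 values shown sits, and its true value is unknown. Compound 3 `COc1ccc2c(=O)c(/C=C/C(=O)Nc3ccccc3C)coc2c1` differs from compound 2 in one place: hydrogen in place of methyl on an aromatic carbon. Among the compounds with values here, no measured pair shows such a change, so the expectation is that a number no higher from compound 2 to compound 3 (the limit leaves the size open) amounts to no step beyond the usual scatter. Compound 3 is therefore estimated at 100000 nM, between 30000 nM and 300000 nM, and may again be reported only as a limit.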

Compound 3, half-maximal inhibitory concentration: 22500 nM
Beside the measured number, compound 3's estimate is 4.4-fold (0.65 log units) above it; the measured number lies below the stated range.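

In this assay, putting hydrogen in place of the methyl, which turns 2,5-dimethylphenyl into 2-methylphenyl, gives an at least 4.4-fold lower number from compound 2 to compound 3 (0.64 log units; beyond the scatter). This is the first readable step among these compounds, and it shows that a single methyl at this position, para to a methyl group, changes the result beyond the usual scatter. The full size of the step remains unknown, as compound 2 has only a limit and not a number: the limit of > 100000 nM in this assay, at which 1 of the 3 values shown sits.

The compounds shown leave open how other groups at this position, such as an amine or a carboxylic acid, would compare with hydrogen. They also leave open whether removing this methyl would have the same effect on a different core.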